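The source may hold more compounds than are shown below. What is called first, only, known or untested is meant among the compounds shown, and "the series" means these compounds.

Measured so far in this set:

- Compound 1, `COc1cc(C)nc2n/c(=N/C(=O)c3c(-c4ccc(Cl)cc4Cl)noc3C)sn12`: 80.6%
- Compound 2, `COc1cc(SC)nc(NC(=S)NC(=O)c2c(-c3ccc(Cl)cc3Cl)noc2C)n1`: 69.2%
- Compound 3, `Cc1onc(-c2ccc(Cl)cc2Cl)c1C(=O)/N=c1/nc2nc(Cl)cc(C)n2s1`: 70.2%

All three were tested in a functional assay on the whole organism for inhibition, with Brassica napus as the target, with a stated time of 72 h, tested at 100 mg/L; on this read-out lower numbers stand for less inhibition of growth and higher numbers for more inhibition of growth at the one concentration tested. Compound 1 gives the highest of the three numbers, 80.6%. The nearest to it is compound 3 with 70.2%, and the furthest is compound 2 with 69.2%; both of these gaps lie beyond the usual scatter of the measurement, so compound 1 is the strongest inhibitor of growth among the measured compounds.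

Compound 4, `COc1cc(OC)n2s/c(=N\C(=O)c3c(-c4ccc(Cl)cc4Cl)noc3C)nc2n1`, has not yet been measured. It is built from compound 1 by one change: methoxy in place of methyl on an aromatic carbon. Among the measured compounds shown here, nothing measured so far shows a step of exactly this kind, so the expectation for compound 4 has to rest on compound 1 alone and on the smallness of the change.

A small group replaced by another small group at one ring position is expected to move the number little. The step from compound 1 to compound 4 in this assay is therefore estimated at a number 6.6 percentage points lower from compound 1 to compound 4 (within the scatter), which would not clearly exceed the scatter. For compound 4 the estimated result in this assay is 74%, with a range from 58% to 88%.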

Compound 4, percent growth inhibition at one concentration: 85.6%
The estimate for compound 4 lay 11.6 percentage points below the measured number; the range from low to high includes it.
By their numbers in this assay, from the lowest: compounds 2 and 3 (each within the scatter of the next); then compounds 1 and 4 (each within the scatter of the next).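

In this assay, the swap of methyl for methoxy on an aromatic carbon of the six-membered ring gives a number 5 percentage points higher from compound 1 to compound 4 (within the scatter) and so leaves compound 1 and compound 4 indistinguishable on this read-out. Among the compounds shown here, this is the first change in a single place that can be read in this set, and it shows that this ring carbon tolerates a group with one more heavy atom, an oxygen that counts as a hydrogen-bond acceptor, with no loss of growth inhibition that rises above the scatter. Nothing available explains why the number holds across this change.

Going by these compounds, it remains open whether an amine, a carboxylic acid or a longer chain such as butoxy on this same aromatic carbon would keep growth inhibition at this level, so the limit of what the position tolerates is not yet visible. On these data alone, with only one concentration tested, it also remains open whether compound 1 and compound 4 would separate at lower doses.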